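Changing the Amine Group on a Weaker Inhibitor

The source may report more compounds than this note shows. Statements on the series, on what has been measured and on what is new or still open speak of the compounds shown alone.

In a functional assay (brain) for inhibition, with Rattus norvegicus as the target (a higher number here means a weaker inhibitor, a lower number a stronger inhibitor), compound 1 `Cc1c(C)c2c(c(C)c1O)C(CN1CCCCC1)C(C)(C)O2` gives 400 nM and compound 2 `Cc1c(C)c2c(c(C)c1O)C(CNC(C)C)C(C)(C)O2` gives 1400 nM, the higher of the two numbers and therefore the weaker inhibitor. Compound 3 `Cc1c(C)c2c(c(C)c1O)C(C[N+](C)(C)C)C(C)(C)O2` keeps the shared core and differs from compound 2 in the group on a saturated chain carbon bound to a saturated ring carbon: a group of 4 heavy atoms (3 carbon, 1 nitrogen; no ring) in place of a group of 4 heavy atoms (3 carbon, 1 nitrogen; no ring), on a saturated chain carbon bound to a saturated ring carbon. Among the compounds with values here, the only measured step changes that same place: a 3.5-fold higher number from compound 1 to compound 2 (0.54 log units; beyond the scatter). That step was modest but beyond the scatter. Within the data shown here, the entering group has a net charge of +1, and no measured compound shows what such a group does here, so any prediction is uncertain. A modest move towards a weaker inhibitor in this assay is the best guess, with an expected step of a 2.1-fold higher number from compound 2 to compound 3 (0.33 log units; beyond the scatter). The estimated value for compound 3 is 3000 nM, with an expected range of 800 nM to 12000 nM.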

Compound 3, half-maximal inhibitory concentration: 3600 nM
Estimate against measurement, compound 3: 1.2-fold (0.08 log units) below; measured number inside the range.
By their numbers in this assay, from the lowest: compound 1; then compound 2; then compound 3.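

At this position, a group with a net charge of +1 and no hydrogen-bond donor or acceptor still gives a measurable number in this assay, with a step of a 2.6-fold higher number from compound 2 to compound 3 (0.41 log units; beyond the scatter). Across the same position, the total span reaches a 9.0-fold higher number from compound 1 to compound 3 (0.95 log units; beyond the scatter), which leaves the piperidin-1-yl group of compound 1 with the lowest number of the three and the entering group of compound 3 with the highest. No supporting measurement is available to explain either step.

Compound 3 gains the charge and loses the hydrogen-bond donor and acceptor in a single change, so the compounds shown cannot separate these differences. A dimethylamino group or a pyrrolidin-1-yl ring at this position would show how other amines compare with these three.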